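Cytotoxicity at the aromatic carbon: pyrimidinyl to pyridinyl

This account rests on a few compounds, and the source may have more. Where it says the series, first, only, none or still open, it means among the compounds named here.

Compound 1 `Cc1cc(C)cc(-c2cnc(Nc3ccc(C#N)cc3)nc2Oc2c(C)cc(C#N)cc2C)c1` gives 39000 nM in an ADME assay on MT4 cells (Homo sapiens) for cytotoxicity, read by MTT assay, with a stated time of 5 days; a higher number here means that more compound is tolerated, a lower number that less compound is tolerated.
Compound 2 `Cc1cc(C#N)cc(C)c1Oc1nc(Nc2ccc(C#N)cc2)ncc1-c1ccco1` reaches only a limit of the assay, > 306000 nM.
Compound 3 `Cc1cc(C#N)cc(C)c1Oc1nc(Nc2ccc(C#N)cc2)ncc1-c1cncnc1` reaches only a limit of the assay, > 298000 nM.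

Compound 3 therefore stands at a limit, as does one other of the three values shown; its position is marked by the limit of > 298000 nM in this assay, at which 1 of the 3 values shown sits. Relative to compound 1 it shows an at least 7.6-fold higher number from compound 1 to compound 3 (0.88 log units; beyond the scatter), and the comparison with compound 2 gives a step that the two limits leave unreadable from compound 2 to compound 3.

Compound 4 `Cc1cc(C#N)cc(C)c1Oc1nc(Nc2ccc(C#N)cc2)ncc1-c1ccncc1` differs from compound 3 by pyridin-4-yl in place of pyrimidin-5-yl on an aromatic carbon. Among the measured compounds shown here, the steps that bear on this are an at least 7.8-fold higher number from compound 1 to compound 2 (0.89 log units; beyond the scatter) and an at least 7.6-fold higher number from compound 1 to compound 3 (0.88 log units; beyond the scatter), both moving from a numeric value to a limit, while a step that the two limits leave unreadable from compound 2 to compound 3 cannot be read. Both heteroaryl replacements at this carbon have ended at a limit, and pyridin-4-yl is the closest analogue of pyrimidin-5-yl among them. Compound 4 is therefore expected to sit near the limit as well, a step of an at least 1.1-fold lower number from compound 3 to compound 4 (0.07 log units; that floor lies within the scatter) that is not expected to go beyond the scatter. The estimate for compound 4 is 250000 nM, ranging from 80000 nM to 400000 nM.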

Compound 4, half-maximal cytotoxic concentration: 28000 nM
Beside the measured number, compound 4's estimate is 8.9-fold (0.95 log units) above it; measured number below the stated range.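

Pyridin-4-yl does not behave like the other two heteroaryl groups at this aromatic carbon: in this assay the change gives an at least 10-fold lower number from compound 3 to compound 4 (1.02 log units; beyond the scatter) and an at least 10-fold lower number from compound 2 to compound 4 (1.03 log units; beyond the scatter) and each of these steps starts from a limit of the assay. Against 3,5-dimethylphenyl the same group gives a 1.4-fold lower number from compound 1 to compound 4 (0.14 log units; within the scatter) and so leaves compound 4 level with compound 1. A heteroaryl ring at this position therefore does not by itself go with the higher tolerated concentration, and pyridin-4-yl, with one ring nitrogen where pyrimidin-5-yl has two, does not keep it.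

The compounds shown give no measured property that accounts for this difference. Also open, on these data alone, is where pyridin-3-yl at this carbon, or an amine on the pyridin-4-yl ring, would fall in this assay.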